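Sulfonyl substituent in the series: methyl to 2-methylphenyl

This account rests on a few compounds, and the source may have more. Where it says the series, first, only, none or still open, it means among the compounds named here.

Measured so far in a functional assay on HeLa cells (Homo sapiens) for inhibition, read by sulforhodamine B assay, with a stated time of 74 h (a lower number here means a stronger inhibitor, a higher number a weaker inhibitor), on the shared core:
compound 1 `Cc1ccc(S(=O)(=O)N2C(=O)COC23C=CC(=O)C=C3)cc1` gives 180 nM
compound 2 `CS(=O)(=O)N1C(=O)COC12C=CC(=O)C=C2` gives 7530 nM

Compound 2 holds the higher of the two numbers and so is the weaker inhibitor of the pair. Compound 3 `Cc1ccccc1S(=O)(=O)N1C(=O)COC12C=CC(=O)C=C2` carries 2-methylphenyl in place of methyl on a sulfonyl sulfur. Among the measured compounds shown here, one measured step bears on this: a 42-fold higher number from compound 1 to compound 2 (1.62 log units; beyond the scatter), with methyl in place of 4-methylphenyl. The change to compound 3 runs the other way, so a large fall in the number is expected in this assay. For the measured compounds named here, no measured compound carries 2-methylphenyl, so a somewhat smaller step is expected. The estimated change is a 22-fold lower number from compound 2 to compound 3 (1.33 log units; beyond the scatter) and it remains uncertain. For compound 3 the expected value is 350 nM, with an estimated range from 100 nM to 1200 nM for the measurement.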

Compound 3, half-maximal inhibitory concentration: 3720 nM
Beside the measured number, compound 3's estimate is 11-fold (1.03 log units) below it, outside the stated range (above it).
By their numbers in this assay, from the lowest: compound 1; then compound 3; then compound 2.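

In this assay, 2-methylphenyl in place of methyl on the sulfonyl sulfur gives a 2.0-fold lower number from compound 2 to compound 3 (0.31 log units; beyond the scatter). This recovers only a small part of the gap between compound 2 and compound 1. Adding an aromatic ring at this position is therefore not enough on its own. The location of the methyl on that ring matters far more, since 2-methylphenyl in place of 4-methylphenyl gives a 21-fold higher number from compound 1 to compound 3 (1.32 log units; beyond the scatter) and the two methylphenyl groups are clearly not interchangeable here, though nothing available accounts for this difference.

The compounds shown leave open how a plain phenyl group would compare with the two methylphenyl groups. From the compounds shown here alone, it is also open whether a chlorine or an amine on the phenyl ring would keep the number low or raise it.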